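The compounds below may be only part of what the source reports. "The series", "measured", "known", "first", "only" and "open" are said of these compounds alone.

Two ureas carry the shared core of compound 1 `O=C(Nc1ccc(-n2ncc3c(Cl)cccc32)cc1)Nc1ccc(Cl)c(C(F)(F)F)c1` with an indazole on one aryl arm. In a functional assay on HepG2 cells (Homo sapiens) for cytotoxicity, read by MTT assay, with a stated time of 72 h (a lower number here means a stronger inhibitor, a higher number a weaker inhibitor), compound 1 gives 1900 nM, the highest of the two numbers shown, and compound 2 `O=C(Nc1ccc(-n2ncc3c(C(F)(F)F)cccc32)cc1)Nc1ccc(C(F)(F)F)cc1` gives 1000 nM; the two lie within the scatter of each other, so no order between them is read. Compound 3 `O=C(Nc1ccc(-n2ncc3cnccc32)cc1)Nc1ccc(Cl)c(C(F)(F)F)c1` is unmeasured. It differs from compound 1 by a group of 9 heavy atoms (6 carbon, 3 nitrogen; one five-membered aromatic ring with 2 hetero atoms, one six-membered aromatic ring with 1 hetero atom) in place of a group of 10 heavy atoms (7 carbon, 2 nitrogen, 1 chlorine; one five-membered aromatic ring with 2 hetero atoms, one six-membered aromatic ring of carbon only), on an aromatic carbon. Going by the values given here, no measured step of this kind is available. The change is expected to be small, likely a modest weakening or none beyond the scatter, as a 1.6-fold higher number from compound 1 to compound 3 (0.20 log units; within the scatter). Compound 3 is estimated at 3000 nM, with a range from 1000 nM to 9000 nM.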

Compound 3, half-maximal inhibitory concentration: 4000 nM
Compound 3: the middle estimate sits 1.3-fold (0.12 log units) below what was measured; the measured number falls inside the stated range.
By their numbers in this assay, from the lowest: compounds 2 and 1 (each within the scatter of the next); then compound 3.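

In this assay, going by these compounds alone, the change at this position, para to a large group, gives the first readable step: a 2.1-fold higher number from compound 1 to compound 3 (0.32 log units; beyond the scatter), a modest rise on leaving the 4-chloro-1H-indazol-1-yl group. The chlorine-bearing group therefore gives the lower number of this pair, so this place on the shared core is not indifferent to change. No measurement at hand bears on why the number rises.

As far as these compounds go, it remains open how a methoxy group or an amine at this place would compare with the chlorine. The step is also untested with the other aryl arm, that of compound 2.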